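A few compounds are considered here, and "the series" means these few. Any claim that something is new, unique, unknown or untested is made for them only; others in the source may bear on it.

Measured compounds:
compound 1, `O=c1cc(Cc2ccncc2)oc2ccccc12`, giving 1240 nM in an assay on V79MZh cells for inhibition of cytochrome P450 11B2, mitochondrial (Homo sapiens), with a stated time of 30 min; on this read-out lower numbers stand for stronger inhibition and higher numbers for weaker inhibition
compound 2, `O=c1c(Cc2c[nH]cn2)coc2ccccc12`, giving 121 nM in this assay

Within the data shown here, compound 2 stands at the lower of the two numbers measured so far, and its nearest neighbour, compound 1, sits at a number that is higher by a margin beyond the usual scatter, so compound 2 is the stronger inhibitor of the pair. The two share the same core, and the differences between them lie both in the ring that hangs from the chain carbon and in where on the core that chain sits; no single-change comparison between measured compounds is available.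

Compound 3, `O=c1c(Cc2cccnc2)coc2ccccc12`, has not yet been measured. It keeps the core and the chain placement of compound 2 and differs only in the hanging ring: pyridin-3-yl in place of 1H-imidazol-4-yl on a saturated chain carbon bound to an aromatic carbon. Among the measured compounds shown here, with no measured step of this kind to lean on, the expected direction is a moderate move toward a higher number, though a step within the scatter cannot be ruled out. In this assay compound 3 is expected to give about 320 nM, within a range of 90 nM to 1200 nM, which corresponds to an estimated step of a 2.6-fold higher number from compound 2 to compound 3 (0.42 log units; beyond the scatter).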

Compound 3, half-maximal inhibitory concentration: > 10000 nM
Compound 3: a limit, no number; the forecaster's own chance of this, stated with the estimate: 3%; at least 31-fold (1.49 log units) between middle value and limit.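

On a saturated chain carbon bound to an aromatic carbon, the identity of the hanging ring turns out to matter greatly: in this assay, putting pyridin-3-yl in place of 1H-imidazol-4-yl gives an at least 82-fold higher number from compound 2 to compound 3 (1.91 log units; beyond the scatter). Among these compounds, this is the first comparison here between compounds that differ in only one place, so it isolates the effect of the ring in a way that compound 1 and compound 2, which differ in both the ring and the chain placement, could not. The result for compound 3 is a limit of the assay and not a number: the limit of > 10000 nM in this assay, at which 1 of the 3 values shown sits.

This single change alters the ring size, the number of ring nitrogens and the number of hydrogen-bond donors all at once, so the compounds shown cannot tell which of these differences accounts for the step. A 1-methyl-1H-imidazol-4-yl group on the same chain carbon would keep the five-membered ring with two nitrogens but lack the hydrogen-bond donor, and how such a compound would compare with compound 2 remains an open question.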